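A few compounds are considered here, and "the series" means these few. Any claim that something is new, unique, unknown or untested is made for them only; others in the source may bear on it.

The measured compounds:

Compound 1 `CN1CCC(N2C[C@@H](C(=O)NCc3cccc(C(F)(F)F)c3Cl)N(C)C2=O)CC1` gives 31.6 nM in a functional assay on HEK293 cells for antagonist activity at P2X purinoceptor 7 (Homo sapiens); a lower number here means a stronger inhibitor, a higher number a weaker inhibitor.
Compound 2 `Cc1ncccc1N1C[C@@H](C(=O)NCc2cccc(C(F)(F)F)c2Cl)N(C)C1=O` gives 5.01 nM in this assay.

Among the compounds with values here, of these two numbers compound 2 holds the lower one; the only comparison available is the step of a 6.3-fold lower number from compound 1 to compound 2 (0.80 log units; beyond the scatter), which sets compound 2 clearly apart from compound 1.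

Compound 3 `Cc1cccc(N2C[C@@H](C(=O)NCc3cccc(C(F)(F)F)c3Cl)N(C)C2=O)n1` has not yet been measured. It differs from compound 2 in a single place: 6-methylpyridin-2-yl in place of 2-methylpyridin-3-yl on an amide-type nitrogen in a ring. Both groups are methyl-bearing pyridines of the same size, so only the arrangement of ring nitrogen and methyl within that ring changes.

Within the data shown here, the one measured step, a 6.3-fold lower number from compound 1 to compound 2 (0.80 log units; beyond the scatter), exchanges one kind of ring for an entirely different kind and therefore says little about moving from one pyridine isomer to another. Among the measured compounds shown here, no measured pair shows such a rearrangement inside the same aromatic ring. The expectation thus rests only on how small the change is: compound 3 is expected to remain close to compound 2, with a step of a 1.6-fold higher number from compound 2 to compound 3 (0.20 log units; within the scatter) that does not go beyond the usual scatter. The estimate for compound 3 in this assay is 8 nM, within 3 nM to 25 nM.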

Compound 3, half-maximal inhibitory concentration: 79.4 nM
Beside the measured number, compound 3's estimate is 9.9-fold (1.00 log units) below it; measured number outside the range, above it.
By their numbers in this assay, from the lowest: compound 2; then compound 1; then compound 3.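

In this assay, the step of a 16-fold higher number from compound 2 to compound 3 (1.20 log units; beyond the scatter) shows that this position, on the amide-type nitrogen in the ring, responds strongly to the arrangement inside a methylpyridine, even though both groups have the same atoms and the same counts of hydrogen-bond donors and acceptors. Having a methylpyridine at this position is therefore not enough on its own to give the lower number: 2-methylpyridin-3-yl improved on 1-methylpiperidin-4-yl with the step of a 6.3-fold lower number from compound 1 to compound 2 (0.80 log units; beyond the scatter), whereas 6-methylpyridin-2-yl falls behind it with the step of a 2.5-fold higher number from compound 1 to compound 3 (0.40 log units; beyond the scatter). No measurement available here bears on why these two isomers differ so much.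

The compounds shown leave open whether the place of the ring nitrogen or the place of the methyl matters more, as both shift together in this change. A 2-methylphenyl group, with carbon where the pyridine has its ring nitrogen, and an unsubstituted pyridin-3-yl group, with no methyl, would help separate these two contributions, and how either would behave in this assay remains an open question.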